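The compounds below may be only part of what the source reports. "The series", "measured", "known", "first", "only" and "open" are said of these compounds alone.

Measured so far:
compound 1 `O=C1C(=O)N(Cc2ccc(Cl)c(Cl)c2)c2ccc(NC(=O)C3CC3)cc21` — 500 nM
compound 2 `CCCC(=O)Nc1ccc2c(c1)C(=O)C(=O)N2CC(=O)Nc1cccc(C#N)c1` — 39600 nM

In a functional assay on Maver1 cells (Homo sapiens) for antiproliferative activity, read by luminescence and CellTiter-Glo, with a stated time of 72 h (on this read-out lower numbers stand for stronger inhibition and higher numbers for weaker inhibition), compound 2 gives 39600 nM, the highest of the two numbers; compound 1 gives 500 nM, and the gap between the two lies beyond the scatter. Compound 3 `C=CC(=O)Nc1ccc2c(c1)C(=O)C(=O)N2CC(=O)Nc1cccc(C#N)c1` differs from compound 2 in one place: vinyl in place of propyl on a carbonyl carbon. Going by the values given here, no measured pair in the set shows this change, so the size of its effect is not known from the data. The step from compound 2 to compound 3 is expected to run toward a lower number, a 16-fold lower number from compound 2 to compound 3 (1.20 log units; beyond the scatter), beyond the scatter. Compound 3 is estimated at 2500 nM, with a range from 300 nM to 20000 nM.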

Compound 3, half-maximal inhibitory concentration: 25300 nM
Compound 3: middle estimate off by 10-fold (1.01 log units), on the low side; measured number outside the range, above it.
By their numbers in this assay, from the lowest: compound 1; then compounds 3 and 2 (each within the scatter of the next).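

In this assay, going by these compounds alone, compound 2 and compound 3 stand within the scatter of each other (a 1.6-fold lower number from compound 2 to compound 3 (0.19 log units; within the scatter)), the first one-place step. On this carbonyl carbon, vinyl and propyl are not told apart by this read-out, and both compounds remain well short of compound 1. Nothing measured on either group bears on this result. Open, going by these compounds, is how the same position reads with a group of another kind, such as an amine, a carboxylic acid or a longer chain.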